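This account rests on a few compounds, and the source may have more. Where it says the series, first, only, none or still open, it means among the compounds named here.

Measured compounds:
compound 1, `CC(=O)c1ccc(OCCCCCOc2ccc3c(=O)cc(C(=O)O)oc3c2)cc1`: 3.5 ug/mL
compound 2, `C=CCc1c(OCCCCCOc2ccc(C(C)=O)cc2)ccc2c(=O)cc(C(=O)O)oc12`: 2.4 ug/mL
compound 3, `CC(=O)c1ccc(OCC(O)COc2ccc3c(=O)cc(C(=O)O)oc3c2)cc1O`: 28 ug/mL

The three compounds were tested in a functional assay on ileum (Cavia porcellus) for antagonist activity, with a stated time of 30 s; a higher number here means a weaker inhibitor, a lower number a stronger inhibitor. Compound 1 and compound 2 share one core and differ at a single place: allyl in place of hydrogen on an aromatic carbon. The change made a step of a 1.5-fold lower number from compound 1 to compound 2 (0.16 log units; within the scatter). Compound 3 has a different core; the difference between the two cores is not broken down here. In this assay compound 3 gives the highest number of the three, and its nearest neighbour is compound 1.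

Compound 4, `C=CCc1c(OCC(O)COc2ccc(C(C)=O)c(O)c2)ccc2c(=O)cc(C(=O)O)oc12`, has not yet been measured. It stands to compound 3 as compound 2 stands to compound 1: allyl in place of hydrogen on an aromatic carbon. The place around the changed atom is described in the same words for both pairs, so this is the same change seen a second time. Going by the values given here, the only guide to its effect is the step from compound 1 to compound 2, which was small. On that basis compound 4 is expected to land close to compound 3, and the expected step is a 1.5-fold lower number from compound 3 to compound 4 (0.17 log units; within the scatter), resting on a 1.5-fold lower number from compound 1 to compound 2 (0.16 log units; within the scatter). The change is the same, and so the number for compound 4 is estimated at 19 ug/mL, with the range 8 ug/mL to 45 ug/mL allowed for the ordinary spread of such measurements.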

Compound 4, half-maximal inhibitory concentration: 3.3 ug/mL
Compound 4: the middle estimate sits 5.8-fold (0.76 log units) above what was measured, outside the stated range (below it).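

On the core of compound 3, allyl in place of hydrogen on an aromatic carbon gave an 8.5-fold lower number from compound 3 to compound 4 (0.93 log units; beyond the scatter) in this assay, and the two pairs do not agree on the size of the step: the same change on two cores in this assay, a 1.5-fold lower number (0.16 log units; within the scatter) from compound 1 to compound 2 and an 8.5-fold lower number (0.93 log units; beyond the scatter) from compound 3 to compound 4, 5.8-fold (0.76 log units) apart, beyond the scatter of two such steps In this series, therefore, the step measured on one core did not serve as a reliable measure of the step on the other, and the effect of this change has to be read separately for each core. Going by these compounds alone, the result does not show which feature is responsible, as the two cores differ in more than one place, and with only two pairs it supports no general rule about where the change will matter.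

The compounds shown leave open whether a propyl group, or a simple methyl group, in place of the allyl would give the same contrast between the two cores, or whether the contrast belongs to allyl alone. They also leave open whether the step would keep its size on either core if an ester or an amide stood in place of the carboxylic acid, or if a longer chain joined the two aromatic parts.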